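Arylidene in place of an ester on an oxindole scaffold

The compounds below may be only part of what the source reports. "The series", "measured", "known", "first", "only" and "open" are said of these compounds alone.

Compound 1 `CCCCc1ccc2c(c1)C(=O)C(=O)N2` carries no substituent on its nitrogen and, in a functional assay on HepG2 cells (Homo sapiens) for antiproliferative activity, read by MTT assay, with a stated time of 48 h (a higher number here means a weaker inhibitor, a lower number a stronger inhibitor), compound 1 reaches only the limit of the assay at > 10000 nM, which is a limit and not a number (the limit of > 10000 nM in this assay, at which 1 of the 3 values shown sits). Compound 2 `COc1ccc(-c2ccc3c(c2)C(=O)C(=O)N3Cc2cc(C)cc(C)c2)cc1`, with a benzyl group on the nitrogen and a methoxyphenyl on the core, gives in this assay a value of 410 nM. Compound 3 `CCOC(=O)/C=C1\C(=O)N(Cc2ccc(OC)cc2)c2ccc(-c3ccc(OC)cc3)cc21`, which bears an ethoxycarbonyl-substituted exocyclic double bond, gives in this assay a value of 3390 nM, the highest of the two numbers shown, with compound 2 sitting well beyond the scatter from it. Compound 4 `COc1ccc(CN2C(=O)/C(=C\c3ccc(C(C)C)cc3)c3cc(-c4ccc(OC)cc4)ccc32)cc1` differs from compound 3 by 4-isopropylphenyl in place of ethoxycarbonyl on a double-bonded chain carbon bound to a double-bonded ring carbon. Within the data shown here, no step between two measured compounds matches this change, so the direction must be judged from the structures alone. In this assay compound 4 is estimated at 1100 nM, within a range of 300 nM to 5000 nM, an expected step of a 3.1-fold lower number from compound 3 to compound 4 (0.49 log units; beyond the scatter) that would bring it nearer the number of compound 2 than that of compound 3.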

Compound 4, half-maximal inhibitory concentration: > 10000 nM
Compound 4 gave a limit, no number; the forecaster's own chance of this, stated with the estimate: 10%; middle value at least 9.0-fold (0.95 log units) away from the limit.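

The exocyclic double-bond position is not open to any group: in this assay, 4-isopropylphenyl in place of ethoxycarbonyl on a double-bonded chain carbon bound to a double-bonded ring carbon gives an at least 2.9-fold higher number from compound 3 to compound 4 (0.46 log units; beyond the scatter). Among these compounds, this is the first comparison in which only this group changes, and it favours the ethoxycarbonyl of compound 3 over the larger, all-carbon aromatic group. Compound 4 gives only a limit, not a number: the limit of > 10000 nM in this assay, at which 2 of the 4 values shown sit.

As far as these compounds go, how much activity is lost therefore stays unknown, and this single step cannot separate the effects of the ring, the missing ester and the isopropyl group. Also open, from the compounds shown here alone, is how a carboxylic acid, an amide or an unsubstituted phenyl would behave on this same carbon.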